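Swapping a dichlorophenyl for a benzyl at the ketone

A few compounds are considered here, and "the series" means these few. Any claim that something is new, unique, unknown or untested is made for them only; others in the source may bear on it.

Two compounds share a central scaffold in which a benzoic acid is linked through a carbonyl to a second benzene ring that in turn carries another carbonyl. Compound 1, `O=C(O)c1ccc(C(=O)c2ccc(C(=O)c3ccc(C(=O)O)cc3)cc2)cc1`, ends in a second 4-carboxyphenyl group, and in an assay on CHO cells for inhibition of 3-oxo-5-alpha-steroid 4-dehydrogenase 2 (Homo sapiens) (a lower number here means a stronger inhibitor, a higher number a weaker inhibitor), compound 1 gives 1000 nM. Within the data shown here, compound 2, `O=C(O)c1ccc(C(=O)c2ccc(C(=O)c3ccc(Cl)c(Cl)c3)cc2)cc1`, carries a 3,4-dichlorophenyl group in that position instead, and in this assay compound 2 gives 35 nM, the lowest of the two numbers measured so far. Among the measured compounds shown here, the only step measured, a 29-fold lower number from compound 1 to compound 2 (1.46 log units; beyond the scatter), shows that this end of the molecule matters greatly.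

Compound 3, `O=C(O)c1ccc(C(=O)c2ccc(C(=O)Cc3ccccc3)cc2)cc1`, changes that same end again: benzyl in place of 3,4-dichlorophenyl on a carbonyl carbon. For the measured compounds named here, no measured step covers a benzyl group here, so the expectation rests on the single step from compound 1 to compound 2. Because compound 2 owes its low number to the dichlorophenyl that gave a 29-fold lower number from compound 1 to compound 2 (1.46 log units; beyond the scatter), removing it is expected to raise the number, though a benzyl keeps an uncharged aromatic ring and should not fall back as far as compound 1. Compound 3 is therefore expected to give about 150 nM, a step of a 4.3-fold higher number from compound 2 to compound 3 (0.63 log units; beyond the scatter), within the range 40 nM to 600 nM.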

Compound 3, inhibition constant: 40 nM
Compound 3: middle estimate off by 3.8-fold (0.57 log units), on the high side; measured number inside the range.
By their numbers in this assay, from the lowest: compounds 2 and 3 (each within the scatter of the next); then compound 1.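

In this assay, the step of a 1.1-fold higher number from compound 2 to compound 3 (0.06 log units; within the scatter) means that benzyl and 3,4-dichlorophenyl cannot be told apart at this end of the molecule, so the chlorine atoms of compound 2 are not required for a number in this range. The step of a 25-fold lower number from compound 1 to compound 3 (1.40 log units; beyond the scatter) adds a second comparison with 4-carboxyphenyl, and among these three compounds, only compound 1, the one ending in 4-carboxyphenyl, stands apart from the others. No measurement available here explains why these groups compare as they do.

The compounds shown leave open whether a plain phenyl on the carbonyl carbon, or a longer chain such as phenylethyl, would stay level with compound 2 and compound 3 or move towards compound 1. An amine at this end, or a benzyl group carrying a carboxylic acid, would help to show whether the carboxylic acid of compound 1 is what sets it apart, a question that three compounds cannot settle.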